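Swapping an amine chain for chlorine on a quinoline-type core

The source may hold more compounds than are shown below. What is called first, only, known or untested is meant among the compounds shown, and "the series" means these compounds.

Measured compounds and their values:
Compound 1, `CN(C)CCCNc1ccnc2cc(OCc3ccc(F)cc3)ccc12`: 1280 nM
Compound 2, `Fc1ccc(COc2ccc3c(Cl)ccnc3c2)cc1`: 2780 nM
Compound 3, `C=CCOc1ccc2c(NCCCN(C)C)ccnc2c1`: 4250 nM

The three measured compounds were tested in a functional assay on SK-OV-3 cells (Homo sapiens) for cytotoxicity, read by MTT assay, with a stated time of 48 h; a higher number here means a weaker inhibitor, a lower number a stronger inhibitor. Compound 1 gives 1280 nM in this assay, compound 2 gives 2780 nM, and compound 3 gives 4250 nM. Compound 2 and compound 3 lie within the scatter of each other, so no order between them can be read.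

The change in question is chloro in place of (3-(dimethylamino)propyl)amino on an aromatic carbon. It has been seen once: a 2.2-fold higher number from compound 1 to compound 2 (0.34 log units; beyond the scatter). Compound 4, `C=CCOc1ccc2c(Cl)ccnc2c1`, is not yet measured; it carries the same change on the core of compound 3, as chloro in place of (3-(dimethylamino)propyl)amino on an aromatic carbon. The two cores differ as vinyl in place of 4-fluorophenyl on a saturated chain carbon bound to an oxygen on an aromatic ring, and the surroundings of the change, described by the same words in both cases, match.

Compound 4 is expected to give a 2.1-fold higher number from compound 3 to compound 4 (0.33 log units; beyond the scatter), beside the earlier step, because the step of a 2.2-fold higher number from compound 1 to compound 2 (0.34 log units; beyond the scatter) was made by the same change on a closely related core. Compound 4 is therefore estimated at 9000 nM, between 4000 nM and 20000 nM.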

Compound 4, half-maximal inhibitory concentration: 4030 nM
For compound 4 the middle estimate is 2.2-fold (0.35 log units) above the measured one; the range from low to high includes it.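

In this assay, the new step, chloro in place of (3-(dimethylamino)propyl)amino on an aromatic carbon, is a 1.1-fold lower number from compound 3 to compound 4 (0.02 log units; within the scatter), so no change can be read on this core. Set beside the earlier step on the other core, the result does not separate from it: the same change on two cores in this assay, a 2.2-fold higher number (0.34 log units; beyond the scatter) from compound 1 to compound 2 and a 1.1-fold lower number (0.02 log units; within the scatter) from compound 3 to compound 4, 2.3-fold (0.36 log units) apart, within the scatter of two such steps. This shows that the two results are compatible with one shared effect of the change, but with a single step on each core it neither proves that the change carries over unchanged nor shows that the core alters it, and a step beyond the scatter on one core and within it on the other is all that can be said.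

The compounds shown leave open how the same change behaves on further cores, for example one whose ether side carries a longer chain or a plain benzyl group. They also leave open what other groups would do at this place, such as bromo, or a piperidine at the end of the amine chain.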